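Toxicity in liver-derived cells after losing an ester group

The source may hold more compounds than are shown below. What is called first, only, known or untested is meant among the compounds shown, and "the series" means these compounds.

Compound 1 `CN(C)c1ccc(/C=C2\C(=O)N(c3ncc(-c4ccc(Cl)cc4)s3)N=C2c2ccccc2)cc1` gives > 206000 nM as a limit
Compound 2 `Cc1ccc(N2C(=O)/C(=C\c3ccccc3)C=C2c2ccccc2)c(Br)c1` gives > 240000 nM as a limit
Compound 3 `CCOC(=O)c1ccc(/C=C2/C=C(c3ccccc3)N(c3ccccc3)C2=O)cc1` gives 112000 nM as a measured number

Going by the values given here, in an ADME assay on Huh-5-2 cells (Homo sapiens) for cytotoxicity, read by MTT assay, with a stated time of 72 h (on this read-out higher numbers stand for lower toxicity in this test and lower numbers for higher toxicity in this test), compound 3 gives 112000 nM as the only true number of the three. The other two values are limits. Compound 4 `O=C1/C(=C\c2ccccc2)C=C(c2ccccc2)N1c1ccccc1` carries hydrogen in place of ethoxycarbonyl on an aromatic carbon, para to a large group hydrogen in place of ethoxycarbonyl on an aromatic carbon in the structure of compound 3. Compound 2 also lacks ethoxycarbonyl, and its > 240000 nM is a limit. Among the compounds with values here, no measured pair isolates this change, so the expected step of a 1.4-fold higher number from compound 3 to compound 4 (0.15 log units; within the scatter) in this assay stays within the scatter, leaning towards a higher number. For compound 4 the estimate is 160000 nM with an expected range from 75000 nM to 320000 nM in this test.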

Compound 4, half-maximal cytotoxic concentration: 30300 nM
Compound 4: middle estimate off by 5.3-fold (0.72 log units), on the high side; measured number outside the range, below it.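

Replacing ethoxycarbonyl with hydrogen on the aromatic ring, para to a large group, makes the compound more toxic in this assay (a 3.7-fold lower number from compound 3 to compound 4 (0.57 log units; beyond the scatter)), so the ester position does affect this read-out. Replacing 2-bromo-4-methylphenyl with phenyl on the amide-type nitrogen in a ring also goes towards higher toxicity (an at least 7.9-fold lower number from compound 2 to compound 4 (0.89 log units; beyond the scatter)). The value of compound 2 in that step is a limit.

Nothing measured here gives a cause for either change. Going by these compounds, how an amine or a carboxylic acid at the ester position would read remains open.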